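Swapping the Side Chain on Compound 1

This account rests on a few compounds, and the source may have more. Where it says the series, first, only, none or still open, it means among the compounds named here.

Compound 1 `Cc1cn([C@@H]2O[C@H](CO[Si](C)(C)C(C)(C)C)[C@@]3(OS(=O)(=O)C=C3NCC(=O)C(=O)N3CCC3)[C@H]2O[Si](C)(C)C(C)(C)C)c(=O)n(C)c1=O` was tested in a functional assay on HEL cells (Homo sapiens) (on this read-out lower numbers stand for higher toxicity in this test and higher numbers for lower toxicity in this test), where compound 1 gives 84400 nM. This is the highest of the two numbers measured in this assay. Compound 3 `C=C(C)C(=O)NC(=O)NC1=CS(=O)(=O)O[C@@]12[C@@H](CO[Si](C)(C)C(C)(C)C)O[C@@H](n1cc(C)c(=O)n(C)c1=O)[C@@H]2O[Si](C)(C)C(C)(C)C` gives 1200 nM, and the step of a 70-fold lower number from compound 1 to compound 3 (1.85 log units; beyond the scatter) comes with ((1-methylethenyl)carbonyl)carbamoyl in place of (((azetidin-1-yl)carbonyl)carbonyl)methyl on an amine nitrogen. Compound 2 `CC(=O)NC1=CS(=O)(=O)O[C@@]12[C@@H](CO[Si](C)(C)C(C)(C)C)O[C@@H](n1cc(C)c(=O)n(C)c1=O)[C@@H]2O[Si](C)(C)C(C)(C)C` reaches only a limit of the assay, > 200000 nM. The step of an at least 2.3-fold higher number from compound 1 to compound 2 (0.37 log units; beyond the scatter) comes with acetyl in place of (((azetidin-1-yl)carbonyl)carbonyl)methyl on the amine nitrogen. Compound 4 `COC(=O)CC(=O)NC1=CS(=O)(=O)O[C@@]12[C@@H](CO[Si](C)(C)C(C)(C)C)O[C@@H](n1cc(C)c(=O)n(C)c1=O)[C@@H]2O[Si](C)(C)C(C)(C)C` has not been measured yet. Its difference from compound 1 is ((methoxycarbonyl)methyl)carbonyl in place of (((azetidin-1-yl)carbonyl)carbonyl)methyl on an amine nitrogen. The entering group, like the acetyl of compound 2, joins the amine nitrogen through a carbonyl, whereas compound 3 carries the ((1-methylethenyl)carbonyl)carbamoyl group; the step to compound 2 therefore bears more closely on this change than the step to compound 3, and a move toward a higher number, or none beyond the scatter, is expected. The estimate for compound 4 is 120000 nM with a range from 40000 nM to 300000 nM. The expected step is a 1.4-fold higher number from compound 1 to compound 4 (0.15 log units; within the scatter).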

Compound 4, half-maximal cytotoxic concentration: 29000 nM
Beside the measured number, compound 4's estimate is 4.1-fold (0.62 log units) above it, and the stated range ends above it.
By their numbers in this assay, from the lowest: compound 3; then compound 4; then compound 1. At a limit, above all of these: compound 2.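

In this assay, the ((methoxycarbonyl)methyl)carbonyl group joins the amine nitrogen through a carbonyl just as the acetyl of compound 2 does, yet this change brings a 2.9-fold lower number from compound 1 to compound 4 (0.46 log units; beyond the scatter), the opposite direction to the step to compound 2, so a carbonyl on this nitrogen does not by itself set the direction of the change. Methoxycarbonyl in place of hydrogen on the acetyl chain gives an at least 6.8-fold lower number from compound 2 to compound 4 (0.83 log units; beyond the scatter), while the ((1-methylethenyl)carbonyl)amino group of compound 3 still stands apart, with a 24-fold higher number from compound 3 to compound 4 (1.38 log units; beyond the scatter). Compound 2 gives a limit of the assay and not a number, so the first of these two steps has a known bound but no known size: the limit of > 200000 nM in this assay, at which 1 of the 4 values shown sits.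

The compounds shown do not separate an effect of the methoxycarbonyl itself from an effect of the longer chain that carries it, and they give no cause for either. A carboxylic acid in place of the methoxycarbonyl, or a plain propanoyl group on the amine nitrogen, would help to tell these two readings apart.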